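The source may report more compounds than this note shows. Statements on the series, on what has been measured and on what is new or still open speak of the compounds shown alone.

Working notes on the series. Compound 1 `CCOC(=O)c1ccc(-c2nn(Cc3ccccc3Cl)c3ccccc23)cc1` in a functional assay on cells (Platelet, Homo sapiens) for inhibition (on this read-out lower numbers stand for stronger inhibition and higher numbers for weaker inhibition), gives only a limit, > 10000 nM. Compound 2 `CCOC(=O)c1ccc(-c2nn(Cc3ccccc3OC)c3ccccc23)cc1` in this assay likewise gives only a limit, > 10000 nM. Compound 3 `CCOC(=O)c1ccc(-c2nn(Cc3ccc(OC)cc3)c3ccccc23)cc1` in this assay also gives only a limit, > 10000 nM. Compound 2 thus stands at the same limit as the other two, (the limit of > 10000 nM in this assay, at which 3 of the 3 values shown sit); every value shown is a limit. The steps a step that the two limits leave unreadable from compound 1 to compound 2, a step that the two limits leave unreadable from compound 1 to compound 3 and a step that the two limits leave unreadable from compound 2 to compound 3 are accordingly not readable in size. Compound 4 `CCOC(=O)c1ccc(-c2nn(C(C)C)c3ccccc23)cc1` carries isopropyl in place of 2-methoxybenzyl on an aromatic nitrogen. Among the measured compounds shown here, no measured step bears readably on this change. Compound 4 is expected to remain at the limit as well, with an estimate of 20000 nM, range 5000 nM to 80000 nM. The expected step is a step that the limit leaves unreadable from compound 2 to compound 4, not readable beyond the scatter.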

Compound 4, half-maximal inhibitory concentration: > 10000 nM
Compound 4 ended at the assay's limit; the forecaster's own chance of this, stated with the estimate: 80%; the middle value lies beyond the limit too.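

Among the compounds shown here, compound 1, compound 2, compound 3 and compound 4 all give only a limit, so no step from any of them to compound 4 can be read. Going by these compounds, whether any group on the aromatic nitrogen allows measurable inhibition stays open.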